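Ethyl to Propyl on the Aryl Urea Core

This account rests on a few compounds, and the source may have more. Where it says the series, first, only, none or still open, it means among the compounds named here.

In an ADME assay on the whole organism with Oryza sativa as the target, tested at 1 uM (on this read-out lower numbers stand for a stronger effect and higher numbers for a weaker effect at the one concentration tested), compound 1 `Cc1ccccc1NC(=O)N[C@H](C)c1ccccc1` gives 100%. Compound 2 `CCc1ccc(NC(=O)N[C@H](C)c2ccccc2)cc1` gives 47%, and compound 3 `CCc1ccc(NC(=O)N[C@@H](C)c2ccccc2)cc1` gives 95%; compound 3 thus stands second highest of the three numbers, within the scatter of compound 1 and far from compound 2. Going by the values given here, the only step measured across a single change, a number 48 percentage points higher from compound 2 to compound 3 (beyond the scatter), rests on the fact that compounds 2 and 3 differ only in the configuration as drawn and so carries no information about lengthening the chain on the ring. Compound 4 `CCCc1ccc(NC(=O)N[C@@H](C)c2ccccc2)cc1` differs from compound 3 by methyl in place of hydrogen on a saturated chain carbon, two bonds along the chain from an aromatic carbon. Among the compounds with values here, since no measured step bears on this change, no movement beyond the scatter is expected, and the expected step is a number 5 percentage points lower from compound 3 to compound 4 (within the scatter). Compound 4 is therefore estimated at 90%, with a range from 65% to 100%.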

Compound 4, a percentage reported as activity, at one concentration (the size of the read-out at that concentration, not a potency): 76%
Compound 4: the middle estimate sits 14 percentage points above what was measured, and the stated range covers the measured number.
By their numbers in this assay, from the lowest: compound 2; then compound 4; then compounds 3 and 1 (each within the scatter of the next).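

In this assay the change from ethyl to propyl gives a number 19 percentage points lower from compound 3 to compound 4 (beyond the scatter) and so shows that the number responds to methyl in place of hydrogen on this saturated chain carbon, two bonds along the chain from an aromatic carbon. Going by these compounds alone, the only earlier step was a change of configuration. Nothing in the evidence at hand accounts for this step.

Still open, going by these compounds, is whether a longer chain, or an amine or a carboxylic acid at this place, would move the number further. On these data alone, it is also open whether ethyl to propyl would act alike in the configuration of compound 2.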